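Chloro for methyl on the shared core: compound 4

A few compounds are considered here, and "the series" means these few. Any claim that something is new, unique, unknown or untested is made for them only; others in the source may bear on it.

Compound 1 `Fc1ccc(-c2noc3c2CCNCC3)cc1`: > 10000 nM
Compound 2 `Cc1ccc(-c2n[nH]c3c2CCNCC3)cc1`: 109 nM
Compound 3 `Cc1ccc(-c2noc3c2CCNCC3)cc1`: 492 nM

In an assay on cells for displacement of a labelled ligand from 5-hydroxytryptamine receptor 6 (Homo sapiens), read by scintillation counting, with a stated time of 1.5 h (on this read-out higher numbers stand for weaker inhibition and lower numbers for stronger inhibition), compound 1 gives only a limit, > 10000 nM (the limit of > 10000 nM in this assay, at which 1 of the 3 values shown sits). Compound 3 gives 492 nM and compound 2 gives 109 nM. Compound 2 stands lowest of the two numbers; compound 3 sits higher, beyond the scatter. Among the measured compounds shown here, the one measured step, an at least 20-fold lower number from compound 1 to compound 3 (1.30 log units; beyond the scatter), exchanges a halogen for methyl.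

Compound 4 `Clc1ccc(-c2n[nH]c3c2CCNCC3)cc1` differs from compound 2 as follows: chloro in place of methyl on an aromatic carbon. For the measured compounds named here, no measured step swaps chloro for methyl, and the halogen-to-methyl step was run on a different core. A modest rise is expected, a 1.8-fold higher number from compound 2 to compound 4 (0.26 log units; within the scatter), smaller than the fluoro case. Compound 4 is estimated at 200 nM (60 nM to 700 nM).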

Compound 4, inhibition constant: 248 nM
Beside the measured number, compound 4's estimate is 1.2-fold (0.09 log units) below it, within the range that was stated.
By their numbers in this assay, from the lowest: compound 2; then compounds 4 and 3 (each within the scatter of the next). At a limit, above all of these: compound 1.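

In this assay, chloro in place of methyl on the aromatic carbon para to a large group gives a 2.3-fold higher number from compound 2 to compound 4 (0.36 log units; beyond the scatter). On this core, the position therefore accepts a halogen with only a modest loss, and methyl keeps the lower number. Nothing measured on hand bears on the reason for this step.

From the compounds shown here alone, whether the same exchange gives a step of similar size on the core of compound 3 remains open. So does the effect of a methoxy group or a nitrile at this position.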